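Swapping the side-chain ring on compound 3

The source may hold more compounds than are shown below. What is called first, only, known or untested is meant among the compounds shown, and "the series" means these compounds.

Compound 1 `CCC(C)n1ncn(-c2ccc(N3CCN(c4ccc(OC[C@@H]5COC(c6ccc(Cl)cc6Cl)O5)cc4)CC3)cc2)c1=O` gives 328 nM
Compound 2 `CCC(C)n1ncn(-c2ccc(N3CCN(c4ccc(OC[C@@H]5CO[C@@](CN(C)C)(c6ccc(Cl)cc6Cl)O5)cc4)CC3)cc2)c1=O` gives 1400 nM
Compound 3 `CCC(C)n1ncn(-c2ccc(N3CCN(c4ccc(OC[C@@H]5CO[C@@](CN6CCN(C)CC6)(c6ccc(Cl)cc6Cl)O5)cc4)CC3)cc2)c1=O` gives 396 nM

In a functional assay on HUVEC cells (Homo sapiens), read by scintillation counting and thymidine incorporation, with a stated time of 24 h (on this read-out higher numbers stand for weaker inhibition and lower numbers for stronger inhibition), compound 3 at 396 nM lies within the usual scatter of compound 1 at 328 nM and well under compound 2 at 1400 nM on this scale. Compound 4 `CCC(C)n1ncn(-c2ccc(N3CCN(c4ccc(OC[C@@H]5CO[C@@](Cn6ccnc6C(C)C)(c6ccc(Cl)cc6Cl)O5)cc4)CC3)cc2)c1=O` changes one group of compound 3 on a saturated chain carbon bound to a saturated ring carbon, with 2-isopropyl-1H-imidazol-1-yl in place of 4-methylpiperazin-1-yl on a saturated chain carbon bound to a saturated ring carbon as the whole difference. Among the measured compounds shown here, only one measured step touches this place: a 3.5-fold lower number from compound 2 to compound 3 (0.55 log units; beyond the scatter) when 4-methylpiperazin-1-yl replaced dimethylamino. That modest step shows that the number can move with this group, yet a single step gives no direction for an aromatic ring entering here. The expected change is therefore small, a 1.3-fold higher number from compound 3 to compound 4 (0.10 log units; within the scatter) with a wide margin on either side. For compound 4 the estimated value in this assay is 500 nM with an expected range of 170 nM to 1500 nM around it.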

Compound 4, half-maximal inhibitory concentration: 84 nM
For compound 4 the middle estimate is 6.0-fold (0.77 log units) above the measured one, and the stated range ends above it.
By their numbers in this assay, from the lowest: compound 4; then compounds 1 and 3 (each within the scatter of the next); then compound 2.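

In this assay, this position accepts an aromatic ring as well as a saturated amine. Putting 2-isopropyl-1H-imidazol-1-yl on the saturated chain carbon gives a 4.7-fold lower number from compound 3 to compound 4 (0.67 log units; beyond the scatter) against 4-methylpiperazin-1-yl and a 17-fold lower number from compound 2 to compound 4 (1.22 log units; beyond the scatter) against dimethylamino. The earlier compounds showed only a change between two amines, whereas this larger step shows that the choice of group here can shift the number much further, though nothing shown gives a reason for the gain.

The compounds shown leave open whether the imidazole ring or its isopropyl group carries the change, since the unsubstituted 1H-imidazol-1-yl group is not among them. They also leave open how another aromatic ring, such as 1H-1,2,4-triazol-1-yl, or a longer chain leading to the imidazole would read.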